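The compounds below may be only part of what the source reports. "The series", "measured", "known", "first", "only" and "open" are said of these compounds alone.

In an ADME assay on MT4 cells (Homo sapiens) for cytotoxicity, read by MTT assay, with a stated time of 5 days (on this read-out lower numbers stand for higher toxicity in this test and higher numbers for lower toxicity in this test), compound 2 `Cc1cccc(C)c1Oc1cc(Nc2ccc(C#N)cc2)[nH]c(=O)c1Cl` gives 29000 nM and compound 1 `Cc1cccc(C)c1Oc1cc(Nc2ccc(C#N)cc2)[nH]c(=O)c1Br` gives 63000 nM. The difference between them is bromo in place of chloro on an aromatic carbon, and this change made a step of a 2.2-fold higher number from compound 2 to compound 1 (0.34 log units; beyond the scatter). Compound 3 `Cc1cc(C)c(Oc2cc(Nc3ccc(C#N)cc3)[nH]c(=O)c2Cl)c(C)c1` differs from compound 2 by methyl in place of hydrogen on an aromatic carbon, and the step is an at least 11-fold higher number from compound 2 to compound 3 (1.05 log units; beyond the scatter). For compound 3 only a limit is known in this assay, > 329000 nM, because its value sits at the limit of > 329000 nM in this assay, at which 1 of the 3 values shown sits. Compound 4 `Cc1cc(C)c(Oc2cc(Nc3ccc(C#N)cc3)[nH]c(=O)c2Br)c(C)c1` is not yet measured; it differs from compound 3 by bromo in place of chloro on an aromatic carbon, the same kind of change as from compound 2 to compound 1, though here the place is ortho to a large group and para to a (4-cyanophenyl)amino group. On the strength of the earlier step of a 2.2-fold higher number from compound 2 to compound 1 (0.34 log units; beyond the scatter) and the limit of compound 3, a step that the limit leaves unreadable from compound 3 to compound 4 is expected, so compound 4 is estimated at 450000 nM, most likely again reported only as a limit.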

Compound 4, half-maximal cytotoxic concentration: > 294000 nM
Compound 4 was reported as a limit (the forecaster's own chance of this, stated with the estimate: 80%); the middle value does not contradict the limit.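

Methyl in place of hydrogen on an aromatic carbon, carried from the chloro core to the bromo core, again gave a higher number in this assay, with an at least 4.6-fold higher number from compound 1 to compound 4 (0.66 log units; beyond the scatter). The direction of this change therefore held on both cores, but its size cannot be compared between them: the same change on two cores in this assay, an at least 11-fold higher number (1.05 log units; beyond the scatter) from compound 2 to compound 3 and an at least 4.6-fold higher number (0.66 log units; beyond the scatter) from compound 1 to compound 4; the limit leaves it open whether they differ Compound 3 and compound 4 are both reported only as limits, so the step between them cannot be read, and these compounds do not show whether bromo in place of chloro carries over to the methyl-bearing core.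

The compounds shown leave open what an amine or a methoxy group in place of the chloro or bromo would give. They also leave open whether an ethyl group in place of the added methyl would give a similar step.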